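A Methyl on the Amide Side Chain of Compound 2

The compounds below may be only part of what the source reports. "The series", "measured", "known", "first", "only" and "open" are said of these compounds alone.

Compound 2 `CCC(=O)NC[C@@H]1C[C@H]1c1cccc2c1C[C@@H](CCCCc1ccccc1)O2` gives 1 nM in an assay on NIH3T3 cells for binding affinity to melatonin receptor type 1A (Homo sapiens); on this read-out lower numbers stand for stronger inhibition and higher numbers for weaker inhibition. Compound 1 `O=C(NC[C@@H]1C[C@H]1c1cccc2c1C[C@@H](CCCCc1ccccc1)O2)C1CC1` gives 1 nM in this assay, and compound 3 `CCC(=O)NCCCc1cccc2c1C[C@@H](CCCCc1ccccc1)O2` gives 1 nM. On these numbers compound 2 stands level with compounds 1 and 3: the step of no change at the digits printed from compound 1 to compound 2 (within the scatter), ethyl in place of cyclopropyl on a carbonyl carbon, and the step of no change at the digits printed from compound 2 to compound 3 (within the scatter), 3-(propanoylamino)propyl in place of 2-((propanoylamino)methyl)cyclopropyl on an aromatic carbon, both stayed within the scatter.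

Compound 4 `CC(C)C(=O)NC[C@@H]1C[C@H]1c1cccc2c1C[C@@H](CCCCc1ccccc1)O2` differs from compound 2 by methyl in place of hydrogen on a saturated chain carbon bound to a carbonyl carbon and a saturated chain carbon. The step that bears on this most closely is no change at the digits printed from compound 1 to compound 2 (within the scatter), which already reshaped the group on the carbonyl carbon without moving the figure, and no change at the digits printed from compound 2 to compound 3 (within the scatter) likewise left the amide region's contribution unchanged. The author therefore expects no step beyond the scatter, a 1.5-fold higher number from compound 2 to compound 4 (0.18 log units; within the scatter). Compound 4 is estimated at 1.5 nM, within a range from 0.5 nM to 5 nM.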

Compound 4, inhibition constant: 6 nM
Compound 4: the middle estimate sits 4.0-fold (0.60 log units) below what was measured, and the stated range ends below it.
By their numbers in this assay, from the lowest: compounds 1, 2 and 3 (each within the scatter of the next); then compound 4.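

In this assay, within the data shown here, the group on the carbonyl carbon proves able to move the figure: ethyl and cyclopropyl could not be told apart, yet methyl in place of hydrogen on the saturated chain carbon brings a 6.0-fold higher number from compound 2 to compound 4 (0.78 log units; beyond the scatter), the first step in this set beyond the scatter. The comparison with the cyclopropyl amide reads the same way, with isopropyl in place of cyclopropyl giving a 6.0-fold higher number from compound 1 to compound 4 (0.78 log units; beyond the scatter). The change therefore stands out against both earlier groups on the carbonyl carbon, and the tolerance seen among compounds 1 and 2 does not extend to isopropyl.

Nothing available here accounts for this step. As far as these compounds go, whether a tert-butyl or a methoxymethyl group on the carbonyl carbon would raise the number further, and whether the same methyl would act alike on the 3-(propanoylamino)propyl chain of compound 3, stays open.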